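Regioisomeric chloroacetamide in the phenoxyphenyl pyrazole series

The source may report more compounds than this note shows. Statements on the series, on what has been measured and on what is new or still open speak of the compounds shown alone.

Measured so far:
compound 1, `O=C(CCl)Nc1cccc(Cn2nc(-c3ccc(Oc4ccccc4)cc3)cc2CO)c1` — 400 nM
compound 2, `CCOC(=O)c1cc(-c2ccc(Oc3ccccc3)cc2)nn1Cc1cccc(NC(=O)CCl)c1` — 400 nM
compound 3, `C/C=C/C(=O)Nc1cccc(Cn2nc(-c3ccc(Oc4ccccc4)cc3)cc2C(=O)O)c1` — 24100 nM

In a functional assay on Z-138 cells (Homo sapiens) for inhibition, read by luminescence and CellTiter-Glo, with a stated time of 72 h (on this read-out lower numbers stand for stronger inhibition and higher numbers for weaker inhibition), compound 2 gives 400 nM, level with compound 1 and together the lowest of the three measured numbers. The step of no change at the digits printed from compound 1 to compound 2 (within the scatter) shows that ethoxycarbonyl in place of hydroxymethyl on the aromatic carbon makes no difference beyond the scatter. Compound 3 sits far higher, but it differs from compound 2 in more than one place, so nothing can be read from it about any single change.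

Compound 4, `CCOC(=O)c1cc(-c2ccc(Oc3ccccc3)cc2)nn1Cc1ccc(NC(=O)CCl)cc1`, carries the change (4-(((chloromethyl)carbonyl)amino)phenyl in place of 3-(((chloromethyl)carbonyl)amino)phenyl on a saturated chain carbon bound to an aromatic nitrogen). Among the measured compounds shown here, no measured step in this assay bears on this change: the only single-point step available, from compound 1 to compound 2, concerns a different part of the shared core, and compound 3 is not a single-point comparator. For the measured compounds named here, the expectation for compound 4 therefore rests on no direct precedent and is set close to compound 2, with wide bounds and a slight lean towards a higher number, giving an expected step of a 2.5-fold higher number from compound 2 to compound 4 (0.40 log units; beyond the scatter) in this assay. On that basis compound 4 is estimated at 1000 nM, within a range of 250 nM to 5000 nM.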

Compound 4, half-maximal inhibitory concentration: 400 nM
Beside the measured number, compound 4's estimate is 2.5-fold (0.40 log units) above it, and the stated range covers the measured number.
By their numbers in this assay, from the lowest: compounds 1, 2 and 4 (each within the scatter of the next); then compound 3.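

In this assay, the new step reads no change at the digits printed from compound 2 to compound 4 (within the scatter), so exchanging 3-(((chloromethyl)carbonyl)amino)phenyl for 4-(((chloromethyl)carbonyl)amino)phenyl on a saturated chain carbon bound to an aromatic nitrogen leaves the number unmoved within the scatter. Among the compounds shown here, the earlier single-place step bore only on the substituent on the aromatic carbon, whereas this one gives the first reading on the group held by the saturated chain carbon, and with ethoxycarbonyl in the shared core this read-out does not separate the two named phenyl groups. No measurement here gives an explanation for this flat result.

Going by these compounds, it remains open whether the same flat result holds with hydroxymethyl in place of ethoxycarbonyl, and whether the 4-substituted phenyl group stays at this level when its chloromethyl is replaced by a vinyl group or its whole amide by a plain amine. Comparisons with compound 3 cannot be read as any single change, so the contribution of its carboxylic acid and of its butenoyl amide to its much higher number stays unresolved.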